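The compounds below may be only part of what the source reports. "The series", "measured", "known", "first", "only" and "open" are said of these compounds alone.

Working notes on the series in an ADME assay on RAW264.7 cells (Mus musculus) for cytotoxicity, read by MTT assay, with a stated time of 24 h, in the absence of a further agent; a lower number here means a stronger inhibitor, a higher number a weaker inhibitor.

Of the compounds shown here, three have been measured, and all three sit only at a limit of the assay. Compound 1 `Cc1noc(CC2OC(=O)c3ccccc32)n1` gives > 40000 nM, which is a limit and not a number. Compound 2 `O=C1OC(Cc2nc(-c3ccccc3)no2)c2ccccc21` gives > 40000 nM, again a limit. Compound 3 `COCCOc1ccc(C(O)C2OC(=O)c3c(OC)cc(OC)cc32)cc1` gives > 40000 nM, also a limit. Among the compounds with values here, the one step between measured compounds that differ in a single place, phenyl in place of methyl on an aromatic carbon, reads a step that the two limits leave unreadable from compound 1 to compound 2, so its size cannot be read. Within the data shown here, the only evidence the data give is the limit of > 40000 nM in this assay, at which 3 of the 3 values shown sit.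

Compound 3 therefore stands nowhere more precisely than at that limit, with the two other values shown sitting at the same limit.

Compound 4 `COc1cc(OC)c2c(c1)C(C(O)c1ccc(OCc3ccc(Br)cc3)cc1)OC2=O` is not yet measured. It differs from compound 3 by 4-bromophenyl in place of methoxymethyl on a saturated chain carbon bound to an oxygen on an aromatic ring.

Among the measured compounds shown here, no measured step bears directly on this change, and the step from compound 1 to compound 2 is unreadable, so no direction or size can be drawn from it. Because every value shown sits at the limit of > 40000 nM in this assay, at which 3 of the 3 values shown sit, compound 4 is expected to stay at the limit as well. The expected step is a step that the limit leaves unreadable from compound 3 to compound 4, meaning no readable change. Compound 4 is estimated at 60000 nM, with a range from 30000 nM to 200000 nM.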

Compound 4, half-maximal inhibitory concentration: > 40000 nM
Compound 4 gave a limit, no number; the forecaster's own chance of this, stated with the estimate: 85%; the middle value is on the limit's open side.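

In this assay compound 4 gives > 40000 nM, which is a limit and not a number. No new step can be read: compound 3 and compound 4 both stand only at a limit. The compounds shown leave open whether any change to this series gives a readable value, and at what concentration one would appear: the limit of > 40000 nM in this assay, at which 4 of the 4 values shown sit.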